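The source may hold more compounds than are shown below. What is called first, only, known or untested is meant among the compounds shown, and "the series" means these compounds.

Notes on the series in a functional assay on KYSE-450 cells (Homo sapiens) for inhibition, read by MTT assay, with a stated time of 48 h; on this read-out lower numbers stand for stronger inhibition and higher numbers for weaker inhibition. Compound 1 `COc1cc(NCc2cccc(O)c2)cc(OC)c1OC` carries hydrogen on the nitrogen and a 3-hydroxybenzyl group; in this assay compound 1 gives 71300 nM. Compound 2 `C/C=C/C(=O)N(Cc1cccc(O)c1)c1cc(OC)c(OC)c(OC)c1` carries the (prop-1-en-1-yl)carbonyl group on that nitrogen, and in this assay compound 2 gives 14700 nM. Taking the (prop-1-en-1-yl)carbonyl group off, (hydrogen in place of (prop-1-en-1-yl)carbonyl on a nitrogen on an aromatic ring), weakens inhibition: a 4.9-fold higher number from compound 2 to compound 1 (0.69 log units; beyond the scatter). Compound 3 `C/C=C/C(=O)N(Cc1ccc(OC)cc1)c1cc(OC)c(OC)c(OC)c1` keeps the (prop-1-en-1-yl)carbonyl group but has 4-methoxybenzyl in place of 3-hydroxybenzyl; in this assay compound 3 gives 420 nM, the lowest number of the three, reached by the large step of a 35-fold lower number from compound 2 to compound 3 (1.54 log units; beyond the scatter). Compound 4 `COc1ccc(CNc2cc(OC)c(OC)c(OC)c2)cc1`, not yet measured, is the counterpart of compound 3 with hydrogen on the nitrogen: the change hydrogen in place of (prop-1-en-1-yl)carbonyl on a nitrogen on an aromatic ring is the same change seen between compound 2 and compound 1, at a place that reads the same way, on a core that differs by 4-methoxyphenyl in place of 3-hydroxyphenyl on a saturated chain carbon bound to an amide-type nitrogen. For the measured compounds named here, the expectation rests on the one earlier instance, a 4.9-fold higher number from compound 2 to compound 1 (0.69 log units; beyond the scatter), a modest loss. For compound 4 the expected step is a 4.8-fold higher number from compound 3 to compound 4 (0.68 log units; beyond the scatter). Compound 4 is thus estimated at 2000 nM, within a range from 600 nM to 8000 nM.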

Compound 4, half-maximal inhibitory concentration: 4890 nM
Beside the measured number, compound 4's estimate is 2.4-fold (0.39 log units) below it; low and high end bracket the measured number.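

In this assay the change hydrogen in place of (prop-1-en-1-yl)carbonyl on a nitrogen on an aromatic ring also weakens inhibition on the core of compound 3 (a 12-fold higher number from compound 3 to compound 4 (1.07 log units; beyond the scatter)), and the two instances can be set side by side: the same change on two cores in this assay, a 4.9-fold higher number (0.69 log units; beyond the scatter) from compound 2 to compound 1 and a 12-fold higher number (1.07 log units; beyond the scatter) from compound 3 to compound 4, 2.4-fold (0.38 log units) apart, within the scatter of two such steps.
The step therefore carries over from the core of compound 2 to the core of compound 3 in direction, and the gap in size gives no ground for treating the two cores differently. For the compounds shown here, this rests on only two pairs in a single cell line and does not show that the step would hold on any other core, nor why the group matters.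

Only hydrogen and (prop-1-en-1-yl)carbonyl appear on that nitrogen, which leaves open how an acetyl group, a saturated butanoyl group or a longer chain would read there. Also open, from the compounds shown here alone, is how a benzyl group carrying an amine or a carboxylic acid would read on either core.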